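From a Carboxy Group to an Isopropyl Amide

A few compounds are considered here, and "the series" means these few. Any claim that something is new, unique, unknown or untested is made for them only; others in the source may bear on it.

Of the compounds shown here, three sharing one core have been tested in a functional assay (trachea) with Cavia porcellus as the target; a lower number here means a stronger inhibitor, a higher number a weaker inhibitor. Compound 1 `CC(=O)OCCn1nc(-c2cccnc2)c2ccccc2c1=O` gives 9770 nM. Compound 2 `CCOC(=O)CCCn1nc(-c2cccnc2)c2ccccc2c1=O` gives 10000 nM, and the comparison shows a 1.0-fold higher number from compound 1 to compound 2 (0.01 log units; within the scatter). Compound 3 `O=C(O)Cn1nc(-c2cccnc2)c2ccccc2c1=O`, which carries a carboxy group, is known only by a limit of the assay, > 100000 nM. Its standing is clear only in comparison: an at least 10-fold higher number from compound 1 to compound 3 (1.01 log units; beyond the scatter), and an at least 10-fold higher number from compound 2 to compound 3 (1.00 log units; beyond the scatter).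

In compound 4 `CC(C)NC(=O)CCCn1nc(-c2cccnc2)c2ccccc2c1=O`, 2-(isopropylcarbamoyl)ethyl stands in place of carboxy on a saturated chain carbon bound to an aromatic nitrogen: 2-(isopropylcarbamoyl)ethyl in place of carboxy on a saturated chain carbon bound to an aromatic nitrogen. Compound 2 carries 2-(ethoxycarbonyl)ethyl at that place, so an at least 10-fold higher number from compound 2 to compound 3 (1.00 log units; beyond the scatter), read in reverse, is the closest guide. An amide is not an ester, so this guide is imperfect. A step of similar size towards a lower number, meaning a stronger inhibitor, is expected in this assay. The expected change is an at least 10-fold lower number from compound 3 to compound 4 (1.00 log units; beyond the scatter). For compound 4 the estimated value is 10000 nM, with an expected range of 2500 nM to 40000 nM.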

Compound 4, half-maximal inhibitory concentration: 64600 nM
Compound 4: the middle estimate sits 6.5-fold (0.81 log units) below what was measured; measured number above the stated range.
By their numbers in this assay, from the lowest: compounds 1 and 2 (each within the scatter of the next); then compound 4. At a limit, above all of these: compound 3.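

In this assay, changing the ester to an amide moves the number: a 6.5-fold higher number from compound 2 to compound 4 (0.81 log units; beyond the scatter), and the gap to the acetoxy compound is of similar size, a 6.6-fold higher number from compound 1 to compound 4 (0.82 log units; beyond the scatter). Going by these compounds alone, compound 1 and compound 2 had stayed within the scatter of each other despite their different chains, so this is the first change on the longer chain that clearly shifts the result. The step away from the carboxy group, an at least 1.5-fold lower number from compound 3 to compound 4 (0.18 log units; that floor lies within the scatter), is only a floor, since its starting point is a limit of the assay: the limit of > 100000 nM in this assay, at which 1 of the 4 values shown sits.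

From the compounds shown here alone, whether the amide itself or its isopropyl part sets the number stays open; a primary amide or a methyl amide at the same carbonyl carbon would separate the two. Also open, going by these compounds, is what an amine or a free carboxylic acid at the end of the chain of compound 2 would give.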